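The compounds below may be only part of what the source reports. "The series", "measured", "known", "first", "only" and "open" are said of these compounds alone.

Measured so far in a functional assay on MCF7 cells (Homo sapiens) for cytotoxicity, read by MTT assay, with a stated time of 24 h; on this read-out lower numbers stand for stronger inhibition and higher numbers for weaker inhibition:

compound 1, `COc1ccc(/C=C2\SC(=O)N(Cc3ccc(C(=O)O)cc3)C2=O)cc1`, gives 48000 nM
compound 2, `O=C(O)c1ccc(CN2C(=O)S/C(=C\c3cccnc3)C2=O)cc1`, gives 100000 nM
compound 3, `O=C(O)c1ccc(CN2C(=O)S/C(=C\c3ccccc3)C2=O)cc1`, gives 100000 nM

On these numbers compound 3 stands level with compound 2, and the two together give the highest number of the three, meaning the weakest inhibition seen. Compound 1 sits below them: a 2.1-fold higher number from compound 1 to compound 3 (0.32 log units; beyond the scatter), and likewise a 2.1-fold higher number from compound 1 to compound 2 (0.32 log units; beyond the scatter). Between compound 2 and compound 3 there is no change at the digits printed from compound 2 to compound 3 (within the scatter).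

Compound 4, `O=C(O)c1ccc(CN2C(=O)S/C(=C\c3cccs3)C2=O)cc1`, differs from compound 3 in one place: thiophen-2-yl in place of phenyl on a double-bonded chain carbon bound to a double-bonded ring carbon.

Two of the measured steps bear on this change, since each also exchanges the aromatic ring at the same place, on a double-bonded chain carbon bound to a double-bonded ring carbon. One of them, no change at the digits printed from compound 2 to compound 3 (within the scatter), lay within the scatter; the other, a 2.1-fold higher number from compound 1 to compound 2 (0.32 log units; beyond the scatter), was modest. As far as these compounds go, exchanging the ring there has so far moved the number by little, and both directions remain open; as compound 3 already sits at the top of the range seen, any change beyond the scatter would more likely be toward a lower number. Compound 4 is therefore expected to give about 80000 nM, somewhere between 30000 nM and 150000 nM. This estimate amounts to a 1.3-fold lower number from compound 3 to compound 4 (0.10 log units; within the scatter) in this assay.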

Compound 4, half-maximal inhibitory concentration: 76000 nM
The estimate for compound 4 lay 1.1-fold (0.02 log units) above the measured number; the measured number falls inside the stated range.
By their numbers in this assay, from the lowest: compounds 1, 4, 2 and 3 (each within the scatter of the next, the first and the last beyond it).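

In this assay, a five-membered aromatic ring holding a sulfur atom behaves at this place, on a double-bonded chain carbon bound to a double-bonded ring carbon, much like the six-membered rings: the exchange for phenyl gives a 1.3-fold lower number from compound 3 to compound 4 (0.12 log units; within the scatter), and the exchange for pyridin-3-yl gives a 1.3-fold lower number from compound 2 to compound 4 (0.12 log units; within the scatter). Compound 4 also stays close to the methoxy-bearing ring, with a 1.6-fold higher number from compound 1 to compound 4 (0.20 log units; within the scatter), so thiophen-2-yl is the one ring here that lies within the scatter of all three others, whereas compound 2 and compound 3 both lie beyond it from compound 1. No measurement at hand speaks to what lies behind these small differences.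

Going by these compounds alone, all the rings at this place so far are plain or carry only methoxy, so it remains open whether a ring bearing an amine, a chlorine or a nitro group would move the number further than these exchanges have. As far as these compounds go, the carboxylic acid is common to all four compounds, and whether an ester or an amide in its place would change the number in this assay also remains open.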